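This account rests on a few compounds, and the source may have more. Where it says the series, first, only, none or still open, it means among the compounds named here.

Working notes on the series. Compound 1 `OCc1cn(Cc2cccc(F)c2)c2ccccc12` is the reference point: in a functional assay on T29Kt1 cells (Homo sapiens) for cytotoxicity, read by sulforhodamine B assay, with a stated time of 3 days (a higher number here means a weaker inhibitor, a lower number a stronger inhibitor), compound 1 gives 20 nM, the lowest of the three numbers to hand. Compound 2 `OCc1cn(Cc2ccccc2Cl)c2ccccc12` gives 2510 nM in this assay, and compound 3 `OCc1cn(Cc2ccc(Cl)cc2Cl)c2ccccc12` gives 1580 nM. How the core of compound 1 differs from that of compound 2 is not broken down here. The step from compound 2 to compound 3 is chloro in place of hydrogen on an aromatic carbon; it made a 1.6-fold lower number from compound 2 to compound 3 (0.20 log units; within the scatter).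

Compound 4 `OCc1cn(Cc2cccc(F)c2)c2ccc(Cl)cc12` is not yet measured. It differs from compound 1 by chloro in place of hydrogen on an aromatic carbon. This is the same kind of change as that from compound 2 to compound 3, but the surroundings differ: here the chloro group enters a six-membered aromatic ring of carbon only that is part of a fused or bridged system of two rings, meta to a fused ring and para to a fused ring, whereas in compound 3 it sits meta to a chloro group and para to a large group. Among the compounds with values here, only one such step is known, and it lay within the scatter, so a small step is expected here too; the estimated step is a 1.3-fold higher number from compound 1 to compound 4 (0.10 log units; within the scatter), resting on compound 1 at 20 nM. For compound 4 the expected value in this assay is 25 nM, with a range estimated from 8 nM to 80 nM.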

Compound 4, half-maximal inhibitory concentration: 160 nM
Estimate against measurement, compound 4: 6.4-fold (0.81 log units) below; the whole stated range lies below it.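

Chloro in place of hydrogen on an aromatic carbon gave an 8.0-fold higher number from compound 1 to compound 4 (0.90 log units; beyond the scatter) in this assay. The change does not carry over as one fixed step between these two cores: the same change on two cores in this assay, a 1.6-fold lower number (0.20 log units; within the scatter) from compound 2 to compound 3 and an 8.0-fold higher number (0.90 log units; beyond the scatter) from compound 1 to compound 4, 13-fold (1.10 log units) apart, beyond the scatter of two such steps. Within the data shown here, with only one pair on each core, and the chloro group in different surroundings in each, this shows that the step depends on its setting, but not whether the core or the place of the chloro group decides its size.

Going by these compounds, it remains open how chloro would behave at the place it holds in compound 4 on the core of compound 2. On these data alone, it also remains open whether a smaller fluoro group, a methoxy group or an amine at that place would give a smaller step than chloro.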